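This account rests on a few compounds, and the source may have more. Where it says the series, first, only, none or still open, it means among the compounds named here.

Working notes on the series. The shared core of compound 1 `Cc1ccccc1C(=O)Nc1sc2c(c1C(N)=O)CCN(C(=S)Nc1ccccc1Cl)C2` is kept in compound 2 `NC(=O)c1c(NC(=O)c2ccccc2I)sc2c1CCN(C(=S)Nc1ccccc1Br)C2` and compound 3 `NC(=O)c1c(NC(=O)c2ccccc2I)sc2c1CCN(C(=S)Nc1ccccc1C(F)(F)F)C2`. In a functional assay on HeLa cells (Homo sapiens) for antiproliferative activity, with a stated time of 24 h (a higher number here means a weaker inhibitor, a lower number a stronger inhibitor), compound 1 gives 35300 nM and compound 3 gives 49200 nM; these two numbers lie within the usual scatter of each other. For compound 2 the assay reports only a limit, > 50000 nM, and no number. For the measured compounds named here, the one measured step, an at least 1.0-fold lower number from compound 2 to compound 3 (0.00 log units; that floor lies within the scatter), starts from that limit of > 50000 nM in this assay, at which 1 of the 3 values shown sits, and shows no change beyond the scatter.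

Compound 4 `Cc1ccccc1C(=O)Nc1sc2c(c1C(N)=O)CCN(C(=S)Nc1ccccc1C(F)(F)F)C2` follows from compound 3 by methyl in place of iodo on an aromatic carbon, that is, (2-iodophenyl)carbonyl to (2-methylphenyl)carbonyl. Going by the values given here, no measured step covers this exchange alone. Compound 1 already carries the (2-methylphenyl)carbonyl group and its value of 35300 nM sits within the scatter of compound 3, so no step beyond the scatter is expected in this assay. The expected step is a 1.3-fold lower number from compound 3 to compound 4 (0.11 log units; within the scatter), within the scatter. Compound 4 is estimated at 38000 nM, with a range from 18000 nM to 50000 nM.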

Compound 4, half-maximal inhibitory concentration: > 50000 nM
Compound 4 was reported as a limit (the forecaster's own chance of this, stated with the estimate: 30%); middle value at least 1.3-fold (0.11 log units) from the limit.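

In this assay compound 4 is reported only as a limit, > 50000 nM, and no number. On the aromatic carbon ortho to a large group, methyl in place of iodo gives an at least 1.0-fold higher number from compound 3 to compound 4 (0.00 log units; that floor lies within the scatter), and with the (2-methylphenyl)carbonyl group held, trifluoromethyl in place of chloro gives an at least 1.4-fold higher number from compound 1 to compound 4 (0.15 log units; that floor lies within the scatter), so neither exchange shows a change beyond the scatter, and each step gives only a floor for its size. Both steps end at a limit, and the compounds with a trifluoromethyl or bromo group on the other aromatic ring now sit mostly there: the limit of > 50000 nM in this assay, at which 2 of the 4 values shown sit.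

Going by these compounds, whether iodo and methyl differ in this assay stays open, as compound 4 carries no number. Also open, on these data alone, is how an amine or a carboxylic acid would read on this aromatic carbon in place of iodo or methyl.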